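One More Methoxy on the 3-Methoxybenzyl Group

This account rests on a few compounds, and the source may have more. Where it says the series, first, only, none or still open, it means among the compounds named here.

Measured so far in a functional assay on BV-2 cells (Mus musculus) for inhibition, read by ELISA, with stated times of 3 h and 12 h; on this read-out higher numbers stand for weaker inhibition and lower numbers for stronger inhibition:
- compound 1 `COC(=O)c1ccc(CN2C(=O)C[C@@H](c3ccccc3Cl)[C@H]([N+](=O)[O-])[C@H]2c2ccc(O)cc2)cc1`: 80 nM
- compound 2 `COc1cccc(CN2C(=O)C[C@@H](c3cc(OC)cc(OC)c3)[C@H]([N+](=O)[O-])[C@H]2c2ccc(O)cc2)c1`: 170 nM

Of these two, compound 2 has the higher number, 170 nM, so it is the weaker inhibitor, and its gap to compound 1 lies beyond the usual scatter of repeat measurements.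

Compound 3 `COc1cc(OC)cc([C@@H]2CC(=O)N(Cc3ccc(OC)c(OC)c3)[C@H](c3ccc(O)cc3)[C@H]2[N+](=O)[O-])c1` has not yet been measured. It turns the 3-methoxybenzyl group of compound 2 into a 3,4-dimethoxybenzyl group: methoxy in place of hydrogen on an aromatic carbon. The new methoxy sits ortho to a methoxy group and para to a large group.

Among the measured compounds shown here, compound 1 and compound 2 differ in more than one place, so no measured pair shows this change alone. In this assay a small change is expected, with no direction beyond the scatter: an estimated 1.1-fold lower number from compound 2 to compound 3 (0.05 log units; within the scatter). The expected value for compound 3 is 150 nM, within an estimated range of 60 nM to 380 nM.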

Compound 3, half-maximal inhibitory concentration: 30 nM
The estimate for compound 3 lay 5.0-fold (0.70 log units) above the measured number; measured number outside the range, below it.
By their numbers in this assay, from the lowest: compound 3; then compound 1; then compound 2.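

In this assay, adding one methoxy to turn the 3-methoxybenzyl group into a 3,4-dimethoxybenzyl group gives a 5.7-fold lower number from compound 2 to compound 3 (0.75 log units; beyond the scatter) and this lies beyond the scatter of repeat measurements. This is the first pair shown that differs in one place, so the effect of the benzyl substituent can now be read without other changes mixed in. A single methoxy, ortho to a methoxy group and para to a large group, is enough to shift the number, but nothing measured here explains the shift.

From the compounds shown here alone, it remains open whether this place specifically needs a methoxy, or whether an ethoxy group or an amine there would give a similar step. Going by these compounds, it is also open whether the same addition would lower the number when the other parts of the molecule differ, as they do in compound 1.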